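A few compounds are considered here, and "the series" means these few. Any claim that something is new, unique, unknown or untested is made for them only; others in the source may bear on it.

Measured so far in a functional assay on a cell-free system (plasma, Oryctolagus cuniculus) for inhibition, with stated times of 5 min, 1 min and 6 min; a lower number here means a stronger inhibitor, a higher number a weaker inhibitor

- Compound 1 `CCOC(=O)c1c(C)nc(-c2cccc(C#N)c2)n1C(C)C` gives 9260 nM
- Compound 2 `CCOCCOn1c(-c2cccc(C#N)c2)nc(C)c1C(=O)OCC` gives 6250 nM

The numbers for compound 2 and compound 1 lie within the scatter of each other, so the two cannot be told apart. The next compound is compound 3 `CCOC(=O)c1c(C)nc(-c2cccc(C#N)c2)n1OCc1ccncc1`, and its difference from compound 2 is pyridin-4-yl in place of ethoxymethyl on a saturated chain carbon bound to an oxygen on an aromatic ring in which 2-ethoxyethoxy gives way to (pyridin-4-yl)methoxy. Among the measured compounds shown here, one measured step bears on this, a 1.5-fold lower number from compound 1 to compound 2 (0.17 log units; within the scatter), and it concerns the same aromatic nitrogen. That single step is a thin basis, and neither measured compound carries a ring in this group. No shift beyond the scatter is therefore expected, although the uncertainty is wide. For compound 3 the estimate is 5000 nM, with a range from 1200 nM to 15000 nM expected. The expected change is a 1.3-fold lower number from compound 2 to compound 3 (0.10 log units; within the scatter), and the measurement is still to come.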

Compound 3, half-maximal inhibitory concentration: 6200 nM
The estimate for compound 3 lay 1.2-fold (0.09 log units) below the measured number, within the range that was stated.
By their numbers in this assay, from the lowest: compounds 3, 2 and 1 (each within the scatter of the next).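

Neither earlier compound carries a ring in this group, and in this assay putting pyridin-4-yl in place of ethoxymethyl gives a 1.0-fold lower number from compound 2 to compound 3 (0.00 log units; within the scatter). Set against isopropyl on the aromatic nitrogen, (pyridin-4-yl)methoxy gives a 1.5-fold lower number from compound 1 to compound 3 (0.17 log units; within the scatter), so neither a ring nor the longer group in this place gives a step beyond the scatter. Nothing available here explains why these groups read alike.

From the compounds shown here alone, whether an amine or a carboxylic acid at the end of the chain, or a longer chain, would give a step beyond the scatter remains open. Also open is whether the ring nitrogen of pyridin-4-yl matters, since a plain phenyl ring is not among these compounds, and the ethyl ester and nitrile stay the same throughout.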